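Dropping One Fluoro from a Bis-benzylidene Cyclohexanone

The compounds below may be only part of what the source reports. "The series", "measured", "known", "first", "only" and "open" are said of these compounds alone.

Measured so far in an assay on isolated protein for inhibition of Alpha glucosidase (Homo sapiens), with stated times of 5 min and 15 min, tested at 50 uM; a lower number here means less inhibition, a higher number more inhibition at the concentration tested (going by the name of the read-out):
- compound 1, `O=C1/C(=C/c2ccccc2)CCC/C1=C\c1ccc(F)c(F)c1`: 37.8%
- compound 2, `O=C(/C=C(O)/C=C/c1cc(O)ccc1O)c1cc(O)ccc1O`: 96.9%
- compound 3, `O=C1/C(=C/c2ccccc2)CCC/C1=C\c1ccc(Cl)c(Cl)c1`: 48.4%

Compound 1 stands lowest of the three numbers. Its nearest neighbour is compound 3, whose inhibition is higher by an amount beyond the usual scatter. Compound 2 has a different skeleton altogether and gives the highest inhibition of the set, far above compound 1.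

Compound 4, `O=C1/C(=C/c2ccccc2)CCC/C1=C\c1cccc(F)c1`, is not yet measured. It differs from compound 1 in one place: hydrogen in place of fluoro on an aromatic carbon. The shared core, the two benzylidene arms and the remaining fluoro group are unchanged.

Among the measured compounds shown here, no measured pair shows exactly this kind of removal, so any expectation rests on the small set in hand. Where compound 1 carries two fluoro groups, compound 3 carries two chloro groups; in this assay compound 3 reaches 48.4%, which hints that the halogen substitution on that ring matters somewhat. Taking one fluoro away is therefore expected to move the inhibition down slightly, or not beyond the scatter, rather than up. The step from compound 1 to compound 4 is estimated as a number 5.8 percentage points lower from compound 1 to compound 4 (within the scatter). Compound 4 is expected to give 32%, with a range from 18% to 46%.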

Compound 4, a percentage reported as inhibition, at one concentration (the size of the read-out at that concentration, not a potency): 39.8%
The estimate for compound 4 lay 7.8 percentage points below the measured number; measured number inside the range.
By their numbers in this assay, from the lowest: compounds 1, 4 and 3 (each within the scatter of the next, the first and the last beyond it); then compound 2.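

In this assay, putting hydrogen in place of the fluoro group on this aromatic carbon, the one ortho to a fluoro group and para to a large group, gives a number 2 percentage points higher from compound 1 to compound 4 (within the scatter), so the measurement cannot tell this pair apart. Among the compounds shown here, this is the first direct reading of a single change: at this position, and at this tested concentration, the fluoro group can be removed without a difference that stands out from ordinary repeat-to-repeat variation. No measured information is available to explain this result.

The compounds shown leave open whether a different group at this same position, such as a methoxy group, an amine or a carboxylic acid, would shift the inhibition beyond the scatter. They also leave open what would happen if the remaining fluoro group were replaced by hydrogen as well, and whether a single-concentration reading like this one would hold up in a full measurement of potency.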